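The source may report more compounds than this note shows. Statements on the series, on what has been measured and on what is new or still open speak of the compounds shown alone.

Working notes on the series. All members share one core and differ only in the group on the aromatic nitrogen of the five-membered ring with three nitrogens. Compound 1 `CCOc1ccc(-n2nncc2CN2C(=O)C3(C(C#N)=C(N)Oc4c3c3nc5ccccc5nc3c3ccccc43)c3ccccc32)cc1` returns a limit in an ADME assay on L02 cells (Homo sapiens) for antiproliferative activity, read by MTT assay, with a stated time of 48 h; on this read-out higher numbers stand for weaker inhibition and lower numbers for stronger inhibition: compound 1 gives > 50000 nM. Compound 2 `Cc1ccc(-n2nncc2CN2C(=O)C3(C(C#N)=C(N)Oc4c3c3nc5ccccc5nc3c3ccccc43)c3ccccc32)cc1Cl` likewise returns a limit: compound 2 gives > 50000 nM. The step that the two limits leave unreadable from compound 1 to compound 2 cannot be read, since both values sit at the limit of > 50000 nM in this assay, at which 2 of the 3 values shown sit. Among the compounds with values here, compound 3 `CCc1ccccc1-n1nncc1CN1C(=O)C2(C(C#N)=C(N)Oc3c(N)cc4nc5ccccc5nc4c32)c2ccccc21` is the one member with a number: in this assay compound 3 gives 22900 nM. Compound 1 and compound 2 return only limits, so no ordering among the three is readable.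

Compound 4 `N#CC1=C(N)Oc2c(N)cc3nc4ccccc4nc3c2C12C(=O)N(Cc1cnnn1-c1cc(Cl)ccc1Cl)c1ccccc12` differs from compound 3 in one place: 2,5-dichlorophenyl in place of 2-ethylphenyl on an aromatic nitrogen. Within the data shown here, no measured step bears on this exchange; the single step recorded, from compound 1 to compound 2, is unreadable and concerns other groups. With compound 3 as the only anchor, compound 4 is expected near it, at an estimated 30000 nM with a range of 10000 nM to 80000 nM in this assay. The step of a 1.3-fold higher number from compound 3 to compound 4 (0.12 log units; within the scatter) is thus expected to stay within the scatter, with a real chance that only a limit is reported.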

Compound 4, half-maximal inhibitory concentration: > 50000 nM
Compound 4 ended at the assay's limit (the forecaster's own chance of this, stated with the estimate: 40%); at least 1.6-fold (0.22 log units) between middle value and limit.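

Within the data shown here, the exchange of 2-ethylphenyl for 2,5-dichlorophenyl on the aromatic nitrogen gives the first readable step, an at least 2.1-fold higher number from compound 3 to compound 4 (0.33 log units; beyond the scatter), in this assay, and it goes towards weaker inhibition, whereas the earlier step between limits could not be read. The two groups carry equal heavy-atom counts and no hydrogen-bond donors or acceptors, so these counts do not separate them, which shows that this position responds to a change that leaves them untouched. The step has a lower bound only, and the true size stays unknown, as most values in the set are limits: the limit of > 50000 nM in this assay, at which 3 of the 4 values shown sit.

Which part of the exchange matters, the loss of ethyl or either chlorine, remains open. Going by these compounds, whether a 2-chlorophenyl or a 2-aminophenyl group would give a number on either side of compound 3 also remains open.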